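This account rests on a few compounds, and the source may have more. Where it says the series, first, only, none or still open, it means among the compounds named here.

Of the compounds shown here, three with a shared core have been measured in a functional assay on HepG2 cells (Homo sapiens) for antiproliferative activity, read by MTT assay; a higher number here means a weaker inhibitor, a lower number a stronger inhibitor. Compound 1 `COc1ccc(-c2ccnc(Nc3ccc([N+](=O)[O-])cc3)n2)cc1` gives 1040 nM, compound 2 `O=[N+]([O-])c1ccc(Nc2nccc(-c3ccc(Br)cc3)n2)cc1` gives 43000 nM, and compound 3 `O=[N+]([O-])c1ccc(Nc2nccc(-c3ccc(Cl)c(Cl)c3)n2)cc1` gives 500 nM. That is the lowest number of the three, which makes compound 3 the strongest inhibitor so far. Compound 4 `O=[N+]([O-])c1ccc(Nc2nccc(-c3ccc(Cl)cc3Cl)n2)cc1` has the same atoms as compound 3, joined differently: 2,4-dichlorophenyl in place of 3,4-dichlorophenyl on an aromatic carbon. Among the compounds with values here, no measured step rearranges a group in this way, so the evidence is only indirect. Swapping the group at this same place has had very uneven results. The change was modest in a 2.1-fold lower number from compound 1 to compound 3 (0.32 log units; beyond the scatter), but large in a 41-fold higher number from compound 1 to compound 2 (1.62 log units; beyond the scatter) and in an 86-fold lower number from compound 2 to compound 3 (1.93 log units; beyond the scatter). Small structural changes here can therefore matter a great deal in this assay. With compound 3 already lowest at 500 nM, a moderate rise beyond the scatter is expected for the new isomer, and a large rise cannot be ruled out. The estimated step is a 3.0-fold higher number from compound 3 to compound 4 (0.48 log units; beyond the scatter). The expected value for compound 4 is 1500 nM, with an estimated range of 250 nM to 15000 nM.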

Compound 4, half-maximal inhibitory concentration: 99300 nM
Estimate against measurement, compound 4: 66-fold (1.82 log units) below; the whole stated range lies below it.
By their numbers in this assay, from the lowest: compound 3; then compound 1; then compound 2; then compound 4.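

In this assay shifting one chlorine on the phenyl ring gives a 200-fold higher number from compound 3 to compound 4 (2.30 log units; beyond the scatter) and that is the largest step in the series. Every earlier step swapped one group for a different one, whereas here the atoms stay the same, so the placement of the chlorines matters on its own, not only which atoms are present. The new isomer also falls behind the other groups, with a 2.3-fold higher number from compound 2 to compound 4 (0.36 log units; beyond the scatter) and with a 95-fold higher number from compound 1 to compound 4 (1.98 log units; beyond the scatter) so that compound 4 is the weakest inhibitor of the four.

As far as these compounds go, it remains open whether a plain phenyl, or a phenyl carrying an amine or a carboxylic acid, would keep the number as low as in compound 3. Nothing in the available data explains the size of this jump.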